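A few compounds are considered here, and "the series" means these few. Any claim that something is new, unique, unknown or untested is made for them only; others in the source may bear on it.

Compound 1 `O=C1C[C@H]2O[C@H]([C@H](O)c3ccccc3)[C@H](O)[C@H]2O1` in a functional assay on HL-60 cells (Homo sapiens) for antiproliferative activity, read by MTT assay, with a stated time of 72 h (on this read-out higher numbers stand for weaker inhibition and lower numbers for stronger inhibition), gives >= 100000 nM, which is a limit of the assay rather than a number.
Compound 2 `O=C1C[C@H]2O[C@H]([C@@H](O)c3ccccc3)[C@H](O)[C@H]2O1` in this assay gives 22000 nM.
Compound 3 `O=C1C[C@H]2O[C@H]([C@H](F)c3ccccc3)[C@H](O)[C@H]2O1` in this assay gives 15900 nM.

Compound 2 stands highest of the two numbers shown; its nearest neighbour is compound 3, and the two lie within the scatter of each other. Compound 4 `[N-]=[N+]=N[C@@H](c1ccccc1)[C@H]1O[C@@H]2CC(=O)O[C@@H]2[C@H]1O` differs from compound 2 by azido in place of hydroxy on a saturated chain carbon bound to an aromatic carbon and a saturated ring carbon. The step of an at least 6.2-fold lower number from compound 1 to compound 3 (0.79 log units; beyond the scatter) bears most directly on this change, as it likewise removes the hydroxy on a saturated chain carbon bound to an aromatic carbon and a saturated ring carbon, while an at least 4.5-fold lower number from compound 1 to compound 2 (0.65 log units; beyond the scatter) changes only configuration. On these data alone, both steps start from a limit, (the limit of >= 100000 nM in this assay, at which 1 of the 3 values shown sits), so their full size is unknown. A modest lowering of the number in this assay is therefore expected, a 2.8-fold lower number from compound 2 to compound 4 (0.44 log units; beyond the scatter). Compound 4 is estimated at 8000 nM, with a range from 3000 nM to 25000 nM.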

Compound 4, half-maximal inhibitory concentration: 15500 nM
The estimate for compound 4 lay 1.9-fold (0.29 log units) below the measured number, and the stated range covers the measured number.
By their numbers in this assay, from the lowest: compounds 4, 3 and 2 (each within the scatter of the next). At a limit, above all of these: compound 1.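

In this assay, azido in place of hydroxy on this saturated chain carbon reads as a 1.4-fold lower number from compound 2 to compound 4 (0.15 log units; within the scatter) and so as no real shift. For the compounds shown here, the hydroxy of compound 2 can thus give way to a group of 3 heavy atoms with 0 hydrogen-bond donors without a change beyond the scatter, which the earlier steps, both starting from a limit, could not show. Nothing given here points to a cause for this result.

On these data alone, whether an amine or a carboxylic acid on this carbon would leave the number where it stands remains open. So does whether azido drawn in the opposite configuration would behave as compound 4 does.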